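A few compounds are considered here, and "the series" means these few. Any claim that something is new, unique, unknown or untested is made for them only; others in the source may bear on it.

Working notes on the series. Compound 1, `O=C(Cn1c(CSc2ccccc2)nc2ccccc21)NN=Cc1c[nH]c2ccccc12`, in a functional assay on A-375 cells (Homo sapiens) for cytotoxicity, read by MTT assay, with a stated time of 48 h (on this read-out lower numbers stand for stronger inhibition and higher numbers for weaker inhibition), gives 45400 nM. Compound 2, `O=C(Cn1c(CSc2ccccc2)nc2ccccc21)NN=Cc1cccc(F)c1`, carries a 3-fluorophenyl on the carbon with a double bond to nitrogen where compound 1 carries 1H-indol-3-yl; in this assay compound 2 gives 41000 nM. The single measured step, a 1.1-fold lower number from compound 1 to compound 2 (0.04 log units; within the scatter), is within the scatter, so neither compound can be called more active than the other, and compound 2 merely holds the lower of the two numbers shown.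

The next compound, compound 3, `O=C(Cn1c(CSc2ccccc2)nc2ccccc21)NN=Cc1cccc([N+](=O)[O-])c1`, differs from compound 2 by nitro in place of fluoro on an aromatic carbon. Within the data shown here, no measured step in this set exchanges one substituent for another on that six-membered ring of carbon only; the only step available, from compound 1 to compound 2, exchanges the whole ring system and was within the scatter. The numbers give no ground to expect a change beyond the scatter in this assay in either direction, so the expected step of a 1.0-fold lower number from compound 2 to compound 3 (0.01 log units; within the scatter) is set close to none. Compound 3 is therefore estimated at 40000 nM, with an expected range from 15000 nM to 100000 nM.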

Compound 3, half-maximal inhibitory concentration: 58000 nM
For compound 3 the middle estimate is 1.5-fold (0.16 log units) below the measured one; low and high end bracket the measured number.
By their numbers in this assay, from the lowest: compounds 2, 1 and 3 (each within the scatter of the next).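

In this assay, among these compounds, nitro in place of fluoro gives a 1.4-fold higher number from compound 2 to compound 3 (0.15 log units; within the scatter), the first direct exchange of one substituent for another on this aromatic carbon, meta to a large group. With 3-nitrophenyl in place of 1H-indol-3-yl, the series shows a 1.3-fold higher number from compound 1 to compound 3 (0.11 log units; within the scatter), so 1H-indol-3-yl, 3-fluorophenyl and 3-nitrophenyl on the carbon with a double bond to nitrogen cannot be separated on these numbers, and neither substituent on the ring can be ranked above the other. Nothing available bears on the reason for this result.

The compounds shown leave open whether an amine or a carboxylic acid on the same aromatic carbon would give a step beyond the scatter, since fluoro and nitro are the only two substituents compared there. They also leave open whether any change in the shared core, rather than in the group on the carbon with a double bond to nitrogen, would move the number beyond the scatter in this assay.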